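The source may hold more compounds than are shown below. What is called first, only, known or untested is meant among the compounds shown, and "the series" means these compounds.

In a functional assay on M21 cells (Homo sapiens) for inhibition, read by sulforhodamine B assay, with a stated time of 48 h (a higher number here means a weaker inhibitor of growth, a lower number a stronger inhibitor of growth), compound 1 (`c1cc(OC2CCCCC2)ccc1NC1=NCCO1`) gives 20800 nM and compound 2 (`c1ccc(COc2ccc(NC3=NCCO3)cc2)cc1`) gives 15900 nM. Compound 3 (`O=C(CCl)NC(=O)Nc1ccc(C2CCCCC2)cc1`), whose core differs from those two, gives 900 nM. That is the lowest of the three numbers, and its gap to each of the others lies beyond the scatter. Compound 4 (`O=C(CCl)NC(=O)Nc1ccc(OC2CCCCC2)cc1`) differs from compound 3 in one place, with cyclohexyloxy in place of cyclohexyl on an aromatic carbon. Among the compounds with values here, no measured pair shows this change on its own, so the expectation is cautious: no step beyond the scatter, if anything a slight move toward a weaker inhibitor of growth. The expected change is a 1.4-fold higher number from compound 3 to compound 4 (0.16 log units; within the scatter). For compound 4 the estimate is 1300 nM, with an expected range of 500 nM to 4000 nM.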

Compound 4, concentration for 50% growth inhibition: 5000 nM
The estimate for compound 4 lay 3.8-fold (0.59 log units) below the measured number; measured number above the stated range.
By their numbers in this assay, from the lowest: compound 3; then compound 4; then compounds 2 and 1 (each within the scatter of the next).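

At this place, on an aromatic carbon, cyclohexyloxy in place of cyclohexyl gives (a 5.6-fold higher number from compound 3 to compound 4 (0.74 log units; beyond the scatter)) in this assay, so this change weakens growth inhibition on the core of compound 3. With cyclohexyloxy held fixed, changing the group on the nitrogen on an aromatic ring gives (a 4.2-fold lower number from compound 1 to compound 4 (0.62 log units; beyond the scatter)), so that group also matters. Nothing available explains either step.

As far as these compounds go, whether the oxygen itself or the extra link length drives the first step stays open. A cyclohexylmethyl or cyclohexylamino group at this place could separate the two.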